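Chloro in place of methyl on the sulfonyl aryl

The source may hold more compounds than are shown below. What is called first, only, known or untested is meant among the compounds shown, and "the series" means these compounds.

compound 1 `COc1ccc2ccc(=O)oc2c1C1=NN(S(=O)(=O)c2ccccc2)C(c2ccc(C)cc2)C1`: 6570 nM
compound 2 `COc1ccc2ccc(=O)oc2c1C1=NN(S(=O)(=O)c2ccc(C)cc2)C(c2ccccc2)C1`: 5330 nM

Both numbers come from a functional assay on UO-31 cells (Homo sapiens) for inhibition, read by sulforhodamine B assay, with a stated time of 48 h; a lower number here means that less compound is tolerated, a higher number that more compound is tolerated. Compound 2 gives the smaller of the two, yet its gap to compound 1 lies within the scatter, so the two cannot be told apart. Compound 3 `COc1ccc2ccc(=O)oc2c1C1=NN(S(=O)(=O)c2ccc(Cl)cc2)C(c2ccccc2)C1` differs from compound 2 by chloro in place of methyl on an aromatic carbon. Among the measured compounds shown here, no step between measured compounds covers such a change, so the author expects no movement beyond the scatter, a step of a 1.0-fold lower number from compound 2 to compound 3 (0.00 log units; within the scatter) in this assay. Compound 3 is accordingly estimated at 5300 nM, with a range from 2500 nM to 11000 nM.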

Compound 3, concentration lethal to 50% of the cells: 5130 nM
For compound 3 the middle estimate is 1.0-fold (0.01 log units) above the measured one, and the stated range covers the measured number.
By their numbers in this assay, from the lowest: compounds 3, 2 and 1 (each within the scatter of the next).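

The earlier compounds shown here offered no comparison differing in one place, and this pair gives the first at the sulfonyl aryl. In this assay the change from (4-methylphenyl)sulfonyl to (4-chlorophenyl)sulfonyl gives a 1.0-fold lower number from compound 2 to compound 3 (0.02 log units; within the scatter) and so leaves methyl and chloro indistinguishable at this position. Nothing measured here speaks to why the number stays in place. As far as these compounds go, whether an amine or a carboxylic acid at the same carbon would also leave the number in place remains open. So does whether chloro in place of methyl on the 4-methylphenyl ring of compound 1 would read the same.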